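The compounds below may be only part of what the source reports. "The series", "measured", "known", "first", "only" and "open" are said of these compounds alone.

Measured in a functional assay on A549 cells (Homo sapiens) for antiproliferative activity, read by MTT assay; on this read-out lower numbers stand for stronger inhibition and higher numbers for weaker inhibition:

- compound 1 `COc1cc2c(Oc3ccc(NC(=O)Nc4ccccc4)cc3)ccnc2cc1OCCCCCCC(=O)NO`: 1650 nM
- compound 2 `COc1cc2c(Oc3ccc(NC(=O)Nc4ccccc4Cl)cc3)ccnc2cc1OCCCCCCC(=O)NO`: 1910 nM
- compound 3 `COc1cc2c(Oc3ccc(NC(=O)Nc4ccccc4C(F)(F)F)cc3)ccnc2cc1OCCCCCCC(=O)NO`: 5280 nM

Among the measured compounds shown here, compound 3 has the highest number of the three, so it is the weakest inhibitor in this assay so far. The next compound, compound 4 `COc1cc2c(Oc3ccc(NC(=O)Nc4ccc(C(F)(F)F)cc4Cl)cc3)ccnc2cc1OCCCCCCC(=O)NO`, differs from it by one change: 2-chloro-4-(trifluoromethyl)phenyl in place of 2-(trifluoromethyl)phenyl on an amide-type nitrogen.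

For the measured compounds named here, no measured compound carries a 2-chloro-4-(trifluoromethyl)phenyl group, so the earlier steps offer only partial guidance. Adding chloro gave a 1.2-fold higher number from compound 1 to compound 2 (0.06 log units; within the scatter), which is within the scatter. Adding trifluoromethyl gave a larger shift, a 3.2-fold higher number from compound 1 to compound 3 (0.51 log units; beyond the scatter), but that group stands elsewhere in 2-(trifluoromethyl)phenyl than in the new group. Replacing chloro with trifluoromethyl gave a 2.8-fold higher number from compound 2 to compound 3 (0.44 log units; beyond the scatter).

Compound 4 keeps chloro, as in compound 2, and moves the trifluoromethyl, so some of the loss seen in compound 3 may be recovered, though the data cannot show this. A modest expected change towards a lower number is a 1.8-fold lower number from compound 3 to compound 4 (0.25 log units; within the scatter). The estimate for compound 4 is 3000 nM, with an expected range from 1300 nM to 7000 nM.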

Compound 4, half-maximal inhibitory concentration: 970 nM
The estimate for compound 4 lay 3.1-fold (0.49 log units) above the measured number, and the stated range ends above it.
By their numbers in this assay, from the lowest: compounds 4, 1 and 2 (each within the scatter of the next); then compound 3.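

At the aromatic group on the amide-type nitrogen, changing to 2-chloro-4-(trifluoromethyl)phenyl gives a 5.4-fold lower number from compound 3 to compound 4 (0.74 log units; beyond the scatter), so trifluoromethyl on this ring does not raise the number in every arrangement. Against the two compounds without trifluoromethyl, the new group makes no clear difference: a 2.0-fold lower number from compound 2 to compound 4 (0.29 log units; within the scatter), and a 1.7-fold lower number from compound 1 to compound 4 (0.23 log units; within the scatter). The effect of adding trifluoromethyl therefore depends on the rest of the ring, not on the group alone: the same change on two cores in this assay, a 3.2-fold higher number (0.51 log units; beyond the scatter) from compound 1 to compound 3 and a 2.0-fold lower number (0.29 log units; within the scatter) from compound 2 to compound 4, 6.3-fold (0.80 log units) apart, beyond the scatter of two such steps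

As far as these compounds go, it remains open how a ring carrying the trifluoromethyl of compound 4 without its chloro would compare, so the contributions of the two groups cannot be separated. Also open, from the compounds shown here alone, is whether a nitrile in place of that trifluoromethyl would give a similar number.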